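Series notes: chloro on the shared core, cytotoxicity

A few compounds are considered here, and "the series" means these few. Any claim that something is new, unique, unknown or untested is made for them only; others in the source may bear on it.

Compound 1 `Cc1cc(C)cc(Cn2c(SCC(=O)Nc3ccccc3Br)nc3ccccc32)c1` is the parent. In an ADME assay on MT4 cells (Homo sapiens) for cytotoxicity (a higher number here means that more compound is tolerated, a lower number that less compound is tolerated), compound 1 gives >= 143000 nM, which is a limit of the assay and not a number. Compound 2 `Cc1cc(C)cc(Cn2c(SCC(=O)Nc3ccccc3Br)nc3ccc(Cl)cc32)c1` differs from compound 1 by chloro in place of hydrogen on an aromatic carbon; in this assay compound 2 gives 174000 nM. The step is a step that the limit leaves unreadable from compound 1 to compound 2, and its size cannot be read because of the limit of >= 143000 nM in this assay, at which 1 of the 3 values shown sits. Compound 3 `Cc1cc(C)cc(Cn2c(SCC(=O)Nc3ccc(S(N)(=O)=O)cc3Cl)nc3ccccc32)c1` carries a different amide-side group; in this assay compound 3 gives 111000 nM, a step of an at least 1.2-fold lower number from compound 1 to compound 3 (0.11 log units; that floor lies within the scatter). Compound 3 and compound 2 lie within the scatter of each other.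

Compound 4 `Cc1cc(C)cc(Cn2c(SCC(=O)Nc3ccc(S(N)(=O)=O)cc3Cl)nc3ccc(Cl)cc32)c1` is not yet measured and differs from compound 3 by chloro in place of hydrogen on an aromatic carbon. The place is the same, word for word, as for the change from compound 1 to compound 2, so this is the same change; the two cores differ by 2-chloro-4-sulfamoylphenyl in place of 2-bromophenyl on an amide-type nitrogen. The earlier step stays unreadable because of the limit of >= 143000 nM in this assay, at which 1 of the 3 values shown sits, so the expectation rests on compound 3 at 111000 nM and on all measured steps sitting within the scatter. Compound 4 is expected to give 120000 nM, between 60000 nM and 240000 nM. That estimate means an expected step of a 1.1-fold higher number from compound 3 to compound 4 (0.03 log units; within the scatter), within the scatter.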

Compound 4, half-maximal cytotoxic concentration: >= 18500 nM
Compound 4: only a limit was reported (the forecaster's own chance of this, stated with the estimate: 15%); the middle value lies beyond the limit too.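

In this assay compound 4 gives >= 18500 nM, which is a limit of the assay and not a number. The steps to compound 4 from compound 3 and from compound 2 cannot be read, and the reason is: the limit of >= 18500 nM in this assay, at which 1 of the 4 values shown sits.

The compounds shown leave open whether chloro in place of hydrogen on an aromatic carbon shifts the tolerated concentration at all, with either amide-side group.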